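The source may report more compounds than this note shows. Statements on the series, on what has been measured and on what is new or still open speak of the compounds shown alone.

Compound 1 `COc1cc(/C=C/C(=O)/C=C/c2cccs2)ccc1OCc1cn(CCCCCOc2cc(=O)oc3ccccc23)nn1`: 34%
Compound 2 `COc1ccccc1/C=C/C(=O)/C=C/c1ccc(OCc2cn(CCCCOc3cc(=O)oc4ccccc34)nn2)c(OC)c1`: 40%
Compound 3 `COc1cc(/C=C/C(=O)/C=C/c2cc(OC)c(OC)c(OC)c2)ccc1OCc1cn(CCCCOc2cc(=O)oc3ccccc23)nn1`: 65%

These numbers come from a functional assay on THP-1 cells (Homo sapiens) for inhibition, read by sulforhodamine B assay, with a stated time of 48 h, tested at 50 uM; on this read-out higher numbers stand for more inhibition of growth at the one concentration tested and lower numbers for less inhibition of growth. There, compound 1 gives 34%, which lies within the usual scatter of compound 2 at 40%. Compound 3 at 65% stands clearly above both.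

The next compound, compound 4 `COc1cc(/C=C/C(=O)/C=C/c2ccco2)ccc1OCc1cn(CCCCCOc2cc(=O)oc3ccccc23)nn1`, differs from compound 1 in a single group: furan-2-yl in place of thiophen-2-yl on a double-bonded chain carbon bound to a double-bonded chain carbon. In plain words, furan-2-yl takes the place of thiophen-2-yl on a double-bonded chain carbon bound to a double-bonded chain carbon.

Going by the values given here, only one measured step touches that place: a number 25 percentage points higher from compound 2 to compound 3 (beyond the scatter). It shows that the read-out can respond to a change there. However, that swap, 3,4,5-trimethoxyphenyl in place of 2-methoxyphenyl, is a much larger change in structure than the one at hand. Among the compounds with values here, it was also measured on a linking chain that differs from the one in compound 1. Within the data shown here, no measured pair compares furan-2-yl with thiophen-2-yl directly, so the expectation remains loose. A swap between two such closely matched rings is expected to give no shift beyond the scatter. The estimated change is a number 2 percentage points higher from compound 1 to compound 4 (within the scatter). For compound 4 the expected value is 36%, with an estimated range from 22% to 50%.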

Compound 4, percent growth inhibition at one concentration: 39%
The estimate for compound 4 lay 3 percentage points below the measured number; low and high end bracket the measured number.
By their numbers in this assay, from the lowest: compounds 1, 4 and 2 (each within the scatter of the next); then compound 3.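

Placing furan-2-yl in place of thiophen-2-yl on a double-bonded chain carbon bound to a double-bonded chain carbon gives, in this assay, a number 5 percentage points higher from compound 1 to compound 4 (within the scatter) and this is the first direct comparison of these two rings at this place. The earlier step at the same place, a number 25 percentage points higher from compound 2 to compound 3 (beyond the scatter) and came from the far larger exchange of 2-methoxyphenyl for 3,4,5-trimethoxyphenyl, so it showed only that the read-out can respond to a change there. The new pair adds a narrower finding: exchanging sulfur for oxygen within a five-membered aromatic ring does not move the result beyond the scatter at this single concentration, and no measurement of the two rings' properties is available to explain that.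

On these data alone, it remains open whether this match between furan-2-yl and thiophen-2-yl would hold with a longer linking chain or at other concentrations. As far as these compounds go, the effect of a ring carrying an amine or a carboxylic acid at this place also remains unknown.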